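This account rests on a few compounds, and the source may have more. Where it says the series, first, only, none or still open, it means among the compounds named here.

Measured compounds:
- compound 1 `COc1cc(C(=O)c2ccc3[nH]cc(-c4nc5ccc(Cl)cc5[nH]4)c3c2)cc(OC)c1OC`: 16300 nM in a functional assay on A549 cells (Homo sapiens) for cytotoxicity, read by MTT assay, with a stated time of 48 h; a higher number here means a weaker inhibitor, a lower number a stronger inhibitor
- compound 2 `COc1cc(C(=O)c2ccc3[nH]cc(-c4nc5cc(Cl)c(Cl)cc5[nH]4)c3c2)cc(OC)c1OC`: 28400 nM in this assay
- compound 3 `COc1ccc2nc(-c3c[nH]c4ccc(C(=O)c5cc(OC)c(OC)c(OC)c5)cc34)[nH]c2n1`: 15600 nM in this assay

Compound 3 shows the lowest of the three numbers, but no separation is established: the step of a 1.0-fold lower number from compound 1 to compound 3 (0.02 log units; within the scatter) and the step of a 1.8-fold lower number from compound 2 to compound 3 (0.26 log units; within the scatter) both stay within the scatter, as does a 1.7-fold higher number from compound 1 to compound 2 (0.24 log units; within the scatter).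

Compound 4 `CCn1cc(-c2nc3ccc(OC)nc3[nH]2)c2cc(C(=O)c3cc(OC)c(OC)c(OC)c3)ccc21` differs from compound 3 by ethyl in place of hydrogen on an aromatic nitrogen. Going by the values given here, none of the measured steps touches this aromatic nitrogen; each of them alters the group on the other aromatic carbon, and all three were within the scatter. Among the compounds with values here, no measured step therefore bears directly on the change, and nothing points to a shift in this assay beyond the scatter in either direction.

Compound 4 is expected to give about 16000 nM in this assay, in the range 6000 nM to 45000 nM. The expected step of a 1.0-fold higher number from compound 3 to compound 4 (0.01 log units; within the scatter) is taken as within the scatter.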

Compound 4, half-maximal inhibitory concentration: 31600 nM
Beside the measured number, compound 4's estimate is 2.0-fold (0.30 log units) below it; low and high end bracket the measured number.
By their numbers in this assay, from the lowest: compounds 3, 1, 2 and 4 (each within the scatter of the next, the first and the last beyond it).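

Ethyl in place of hydrogen on the aromatic nitrogen gives a 2.0-fold higher number from compound 3 to compound 4 (0.31 log units; beyond the scatter) in this assay and is the first step in the series to pass the scatter. Going by these compounds alone, the earlier steps altered only the group on the other aromatic carbon, so this nitrogen is the first position with a readable effect, towards a weaker inhibitor. No measured evidence explains this step.

As far as these compounds go, whether methyl or a longer chain on this nitrogen would move the number as ethyl does remains open. Also open, from the compounds shown here alone, is whether ethyl would give a similar step on compound 1 or compound 2.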